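The source may hold more compounds than are shown below. What is called first, only, known or untested is meant among the compounds shown, and "the series" means these compounds.

Working notes on the series.

Compound 1 `CC1(C)[C@H]2CC[C@]1(C)N(Cc1cn(-c3ccc(Cl)cc3)nn1)C(=O)C2` is the reference point. In a functional assay on A549 cells (Homo sapiens) for inhibition, read by MTT assay, with a stated time of 24 h (a higher number here means a weaker inhibitor, a lower number a stronger inhibitor), compound 1 gives 70 nM, which is the second highest of the three numbers in hand; its nearest neighbour is compound 3 `COc1ccc(-n2cc(CN3C(=O)C[C@@H]4CC[C@@]3(C)C4(C)C)nn2)cc1`, which in this assay gives 50 nM, and its furthest is compound 2 `CC1(C)[C@H]2CC[C@]1(C)N(Cc1cn(-c3ccccc3O)nn1)C(=O)C2`, which in this assay gives 230 nM. Between them, a 1.4-fold lower number from compound 1 to compound 3 (0.15 log units; within the scatter) and a 3.3-fold higher number from compound 1 to compound 2 (0.52 log units; beyond the scatter); the remaining pair shows a 4.6-fold lower number from compound 2 to compound 3 (0.66 log units; beyond the scatter).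

Compound 4 `CC1(C)[C@H]2CC[C@]1(C)N(Cc1cn(-c3cccc(F)c3)nn1)C(=O)C2` has not yet been measured. It differs from compound 1 in one place: 3-fluorophenyl in place of 4-chlorophenyl on an aromatic nitrogen.

Which of the measured steps bear on this? The step of a 1.4-fold lower number from compound 1 to compound 3 (0.15 log units; within the scatter) exchanges one group on the aromatic carbon for another and stays within the scatter, so a change of the group on this phenyl ring need not move the number. The step of a 3.3-fold higher number from compound 1 to compound 2 (0.52 log units; beyond the scatter) moves the group to another place on the phenyl ring and replaces it by a hydroxy, and does move the number. Compound 4 keeps a small group but shifts its place, so a small rise in this assay, or none beyond the scatter, is the expectation. The estimate for compound 4 is 100 nM, with a range from 40 nM to 250 nM, which is expected to mean a 1.4-fold higher number from compound 1 to compound 4 (0.15 log units; within the scatter).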

Compound 4, half-maximal inhibitory concentration: 180 nM
Beside the measured number, compound 4's estimate is 1.8-fold (0.26 log units) below it; low and high end bracket the measured number.
By their numbers in this assay, from the lowest: compounds 3 and 1 (each within the scatter of the next); then compounds 4 and 2 (each within the scatter of the next).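

In this assay, the 3-fluorophenyl group gives a 2.6-fold higher number from compound 1 to compound 4 (0.41 log units; beyond the scatter) and a 3.6-fold higher number from compound 3 to compound 4 (0.56 log units; beyond the scatter), so a rise beyond the scatter at this aromatic nitrogen does not require the hydroxy group of compound 2; 3-fluorophenyl, like the 4-chlorophenyl it replaces, is counted with no hydrogen-bond donors or acceptors. With a 1.3-fold lower number from compound 2 to compound 4 (0.11 log units; within the scatter), the 3-fluorophenyl and 2-hydroxyphenyl groups are not separated, and among these four compounds the numbers fall into two groups, with 4-chlorophenyl and 4-methoxyphenyl on the lower side and no compound shown going against this. Nothing measured here gives a reason for this split.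

The step from compound 1 to compound 4 changes the halogen and its place on the phenyl ring together, so the compounds shown cannot tell these two changes apart; 4-fluorophenyl and 3-chlorophenyl would separate them. Also open, on these data alone, is how the unsubstituted phenyl group, or a phenyl ring carrying an amine or a carboxylic acid, would read in this assay.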